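The compounds below may be only part of what the source reports. "The series", "measured", "known", "first", "only" and "open" are said of these compounds alone.

Measured so far in a functional assay on OVCAR-3 cells (Homo sapiens) for inhibition, read by sulforhodamine B assay, with a stated time of 48 h; on this read-out higher numbers stand for weaker inhibition of growth and lower numbers for stronger inhibition of growth:
compound 1, `COc1cc(/C=C/C2CC=CC(=O)O2)cc(OC)c1OC`, gives 44.9 uM;
compound 2, `O=C1C=CCC(/C=C/c2ccccc2)N1`, gives > 1250 uM, a limit of the assay rather than a number;
compound 3, `O=C1C=CCC(/C=C/c2ccc(C(F)(F)F)cc2)N1`, gives 126 uM.

Compound 3 thus holds the highest of the two numbers, with compound 1 at 44.9 uM the nearest and lower. For the measured compounds named here, the only measured step, an at least 9.9-fold lower number from compound 2 to compound 3 (0.99 log units; beyond the scatter), concerns trifluoromethyl in place of hydrogen and so bears only loosely on what follows. Compound 4, `COc1ccc(/C=C/C2CC=CC(=O)N2)cc1`, differs from compound 3 by methoxy in place of trifluoromethyl on an aromatic carbon. Going by the values given here, no measured pair covers methoxy against trifluoromethyl on this core, so no step beyond the scatter is expected. Compound 4 is therefore estimated at 130 uM, within 40 uM to 450 uM, an expected step of a 1.0-fold higher number from compound 3 to compound 4 (0.01 log units; within the scatter).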

Compound 4, concentration for growth inhibition (reported as GI): 787 uM
Compound 4: the middle estimate sits 6.1-fold (0.78 log units) below what was measured; measured number above the stated range.
By their numbers in this assay, from the lowest: compound 1; then compound 3; then compound 4. At a limit, above all of these: compound 2.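

At this aromatic carbon, the identity of the group matters as well as its presence: methoxy in place of trifluoromethyl gives a 6.2-fold higher number from compound 3 to compound 4 (0.80 log units; beyond the scatter). Methoxy in place of hydrogen gives an at least 1.5-fold lower number from compound 2 to compound 4 (0.20 log units; that floor lies within the scatter), so no gain for methoxy over hydrogen can be claimed from this floor. The value of compound 2 is a limit and not a number: the limit of > 1250 uM in this assay, at which 1 of the 4 values shown sits.

Open, going by these compounds, is where an amine or a carboxylic acid at this carbon would fall relative to compound 3 and compound 4. Also open, on these data alone, is whether trifluoromethyl keeps its lead over methoxy on the core of compound 1.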